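A few compounds are considered here, and "the series" means these few. Any claim that something is new, unique, unknown or untested is made for them only; others in the source may bear on it.

Compounds measured in a functional assay on isolated protein for agonist activity at Glucose-dependent insulinotropic receptor (Rattus norvegicus), read by HTRF and cAMP accumulation; a higher number here means that more compound is needed for the effect, a lower number that less compound is needed:

- compound 1, `CC(C)(C)OC(=O)N1CCC(O[C@H]2CC[C@@H](Oc3ccc(S(C)(=O)=O)cc3)CC2)CC1`: 1390 nM
- compound 2, `CC(C)(C)OC(=O)N1CCC(O[C@H]2CC[C@H](Oc3ccc(S(C)(=O)=O)cc3)CC2)CC1`: 94 nM
- compound 3, `CC(C)(C)OC(=O)N1CCC(O[C@H]2CC[C@H](Oc3ccc(S(C)(=O)=O)c(F)c3)CC2)CC1`: 167 nM

Compound 2 and compound 3 sit within the usual scatter of each other, and both stand well apart from compound 1. The large step of a 15-fold lower number from compound 1 to compound 2 (1.17 log units; beyond the scatter) rests on (the fact that compounds 1 and 2 differ only in the configuration as drawn), so the arrangement of the two ring centres alone decides between a weak and a strong result. The small step of a 1.8-fold higher number from compound 2 to compound 3 (0.25 log units; within the scatter) shows that a change on the aromatic ring can pass without a clear effect.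

Compound 4, `CC(C)(C)OC(=O)N1CCC(O[C@H]2CC[C@H](Oc3ccc(C#N)cc3)CC2)CC1`, keeps the ring configuration of compound 2 and changes the aromatic substituent: cyano in place of methylsulfonyl on an aromatic carbon. Neither measured step tests this exchange directly. The stereochemical step concerns a different part of the molecule, and the fluorine step only shows that a small addition on the ring stays within scatter. A larger exchange at the same ring is therefore uncertain, and a somewhat higher number is expected for compound 4, though a result within scatter of compound 2 remains possible.

For compound 4 the estimate is 250 nM, between 80 nM and 800 nM, an expected step of a 2.7-fold higher number from compound 2 to compound 4 (0.42 log units; beyond the scatter).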

Compound 4, half-maximal effective concentration: 45 nM
For compound 4 the middle estimate is 5.6-fold (0.74 log units) above the measured one; the measured number lies below the stated range.
By their numbers in this assay, from the lowest: compound 4; then compounds 2 and 3 (each within the scatter of the next); then compound 1.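

Until now every compound carried methylsulfonyl at this position, so the group might have been essential to the result in this assay; the exchange gives a 2.1-fold lower number from compound 2 to compound 4 (0.32 log units; beyond the scatter), which shows that, on an aromatic carbon para to a large group and with the ring configuration of compound 2, it can give way to cyano without any loss. The incoming group has fewer heavy atoms and fewer hydrogen-bond acceptors than the one it replaces, and the number still falls, so in this single pair neither a larger group nor the sulfur atom is required for a low number. Nothing measured here explains why this exchange lowers the number.

One pair cannot show whether the gain extends to other groups at this position, such as a carboxylic acid, an amine, a methyl or a trifluoromethyl. On these data alone, it also remains open whether cyano would give a similar step in the ring configuration of compound 1, or alongside the fluoro group of compound 3.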